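Bromo substitution on two related cores, cytotoxicity compared

This account rests on a few compounds, and the source may have more. Where it says the series, first, only, none or still open, it means among the compounds named here.

Going by the values given here, compound 1 `CCCNC(=O)C1CCN(C(=O)c2cc3ncsc3n2Cc2ccc(OC)cc2)CC1` is the only one of three measured compounds with a number: in an ADME assay on HEK-293T cells (Homo sapiens) for cytotoxicity, read by luminescence and CellTiter-Glo, with a stated time of 24 h (on this read-out lower numbers stand for higher toxicity in this test and higher numbers for lower toxicity in this test), compound 1 gives 42700 nM. Compound 2 `CCCNC(=O)C1CCN(C(=O)c2cccn2Cc2ccc(OC)cc2)CC1` gives > 100000 nM, which is a limit of the assay. Compound 3 `CCCNC(=O)C1CCN(C(=O)c2ccc(Br)n2Cc2ccc(OC)cc2)CC1` gives > 100000 nM, also a limit. The change bromo in place of hydrogen on an aromatic carbon therefore gives a step that the two limits leave unreadable from compound 2 to compound 3. How the core of compound 1 differs from that of compound 2 is not broken down here. Compound 4 `CCCNC(=O)C1CCN(C(=O)c2cc3nc(Br)sc3n2Cc2ccc(OC)cc2)CC1` carries the same kind of change, (bromo in place of hydrogen on an aromatic carbon), but on a five-membered aromatic ring with one nitrogen and one sulfur within a fused system, next to the ring sulfur, rather than next to the ring atom bearing the 4-methoxybenzyl group. Because the limit of > 100000 nM in this assay, at which 2 of the 3 values shown sit, leaves the measured step unreadable, only a small step is expected from compound 1, a 1.2-fold lower number from compound 1 to compound 4 (0.09 log units; within the scatter). Compound 4 is estimated at 35000 nM, between 12000 nM and 100000 nM.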

Compound 4, half-maximal cytotoxic concentration: 46800 nM
The estimate for compound 4 lay 1.3-fold (0.13 log units) below the measured number, and the stated range covers the measured number.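

On the five-membered aromatic ring with 1 nitrogen and 1 sulfur, bromo in place of hydrogen gives a 1.1-fold higher number from compound 1 to compound 4 (0.04 log units; within the scatter) in this assay, so on this core the change leaves the cytotoxicity reading effectively unchanged. The same change on the core of compound 2, leading to compound 3, cannot be read, because both compounds give a limit rather than a number: the limit of > 100000 nM in this assay, at which 2 of the 4 values shown sit. This leaves one readable case, which does not show that the change has the same size on both cores. As far as these compounds go, whether a chloro, a methyl or an amine on that same aromatic carbon would also stay within the scatter remains open. These compounds also leave open whether a carboxylic acid there would behave differently.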